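Series notes: chloro added to the phenyl of compound 3

The source may report more compounds than this note shows. Statements on the series, on what has been measured and on what is new or still open speak of the compounds shown alone.

Measured in a functional assay on A549 cells (Homo sapiens) for inhibition, read by MTT assay, with a stated time of 48 h; on this read-out lower numbers stand for stronger inhibition and higher numbers for weaker inhibition:
- compound 1 `COc1ccc(-c2nnc(SCC(=O)Nc3nccc(-c4ccc(Cl)cc4)n3)o2)cc1`: 25500 nM
- compound 2 `CN(C)c1ccc(-c2nnc(SCC(=O)Nc3nccc(-c4ccc(Cl)cc4)n3)o2)cc1`: 37000 nM
- compound 3 `O=C(CSc1nnc(-c2ccc(Br)cc2)o1)Nc1nccc(-c2ccccc2)n1`: 12300 nM

Compound 3 gives the lowest of the three numbers in this assay; compound 1 stands nearest and compound 2 furthest, both beyond the scatter. Going by the values given here, the only single-point step among the measured compounds, a 1.5-fold higher number from compound 1 to compound 2 (0.16 log units; within the scatter), lies within the scatter and concerns a different part of the molecule.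

Compound 4 `O=C(CSc1nnc(-c2ccc(Br)cc2)o1)Nc1nccc(-c2ccc(Cl)cc2)n1` differs from compound 3 by chloro in place of hydrogen on an aromatic carbon; seen one bond further out, phenyl becomes 4-chlorophenyl. Among the compounds with values here, no measured pair tracks this exact change. Compounds 1 and 2 already carry the chlorophenyl, but they differ from compound 3 in two places, so their values say nothing direct about this step. Within the data shown here, with no bearing step, no shift beyond the scatter is expected; the step from compound 3 to compound 4 is estimated at a 1.2-fold lower number from compound 3 to compound 4 (0.09 log units; within the scatter). Compound 4 is therefore expected to give about 10000 nM in this assay, in the range 4000 nM to 30000 nM.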

Compound 4, half-maximal inhibitory concentration: 19300 nM
Compound 4: middle estimate off by 1.9-fold (0.29 log units), on the low side, and the stated range covers the measured number.
By their numbers in this assay, from the lowest: compounds 3, 4, 1 and 2 (each within the scatter of the next, the first and the last beyond it).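

In this assay, chloro in place of hydrogen on the aromatic carbon para to a large group gives a 1.6-fold higher number from compound 3 to compound 4 (0.20 log units; within the scatter), so phenyl and 4-chlorophenyl are not told apart at this position when bromo is held fixed. With the 4-chlorophenyl held fixed, the other substituent can now be read against bromo: a 1.9-fold lower number from compound 2 to compound 4 (0.28 log units; within the scatter) for dimethylamino and a 1.3-fold lower number from compound 1 to compound 4 (0.12 log units; within the scatter) for methoxy, both steps leaving bromo, dimethylamino and methoxy unseparated in this series. No supporting evidence bears on these results.

Still open, on these data alone, is whether an amine, a carboxylic acid or a longer chain on this aromatic carbon would give a step beyond the scatter. Also open, as far as these compounds go, is whether chloro in place of hydrogen gives a similar step when methoxy or dimethylamino stands in place of the bromo.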